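Swapping a pyridinyl for a phenyl on the shared core

The compounds below may be only part of what the source reports. "The series", "measured", "known", "first", "only" and "open" are said of these compounds alone.

Compound 1 `O=C(CN1CCN(c2nnc(Cc3ccncc3)c3ccccc23)CC1)Nc1cccc(Br)c1` and compound 2 `O=C(CN1CCN(c2nnc(Cc3ccncc3)c3ccccc23)CC1)Nc1ccc(Br)cc1` share a core and differ only in where the bromine sits on the aniline-derived ring. In a functional assay on A549 cells (Homo sapiens) for cytotoxicity, read by MTT assay, with a stated time of 72 h (on this read-out lower numbers stand for stronger inhibition and higher numbers for weaker inhibition), compound 1 gives 1530 nM, and compound 2 gives 2710 nM. Within the data shown here, the step of a 1.8-fold higher number from compound 1 to compound 2 (0.25 log units; within the scatter) is the only measured comparison, and it leaves compound 2 with the highest of the two numbers, its nearest neighbour being compound 1 at a distance that stays within the scatter.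

Compound 3 `O=C(CN1CCN(c2nnc(Cc3ccccc3)c3ccccc23)CC1)Nc1ccc(Br)cc1` is not yet measured. It differs from compound 2 in one place: phenyl in place of pyridin-4-yl on a saturated chain carbon bound to an aromatic carbon. Among the measured compounds shown here, no measured step touches this part of the molecule; the bromine-position step says nothing about a phenyl in place of a pyridin-4-yl. With no evidence either way, the expected change is none beyond the scatter, as a 1.1-fold lower number from compound 2 to compound 3 (0.04 log units; within the scatter). Compound 3 is therefore estimated at 2500 nM, within 900 nM to 7000 nM.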

Compound 3, half-maximal inhibitory concentration: 2000 nM
Beside the measured number, compound 3's estimate is 1.3-fold (0.10 log units) above it, and the stated range covers the measured number.
By their numbers in this assay, from the lowest: compounds 1, 3 and 2 (each within the scatter of the next).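

In this assay, putting phenyl in place of pyridin-4-yl on a saturated chain carbon bound to an aromatic carbon gives a 1.4-fold lower number from compound 2 to compound 3 (0.13 log units; within the scatter). Among these compounds, this is the first measured step at this part of the molecule, which the bromine-position step did not reach. In this single pair with the 4-bromophenyl group, the change from (pyridin-4-yl)methyl to benzyl removes the ring nitrogen and the one hydrogen-bond acceptor counted for pyridin-4-yl, with no change beyond the scatter. No supporting measurement is available to explain this result.

On these data alone, whether the same exchange would stay within the scatter with the 3-bromophenyl group of compound 1 remains open. So does the effect of an amine or a carboxylic acid on the phenyl ring, or of a longer chain in place of the single saturated chain carbon.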